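Pyrazole amide series: piperidine to dimethylaminomethyl swap

The source may report more compounds than this note shows. Statements on the series, on what has been measured and on what is new or still open speak of the compounds shown alone.

For the measured compounds named here, compound 1 `CN1CCC(C(=O)Nc2n[nH]c3c2CN(C(=O)C(C)(C)C)C3(C)C)CC1` gives 350 nM in a functional assay on A2780 cells (Homo sapiens) for antiproliferative activity, read by fluorescence, with a stated time of 72 h (a higher number here means a weaker inhibitor, a lower number a stronger inhibitor), and carries the only number in this set. Compound 2 `CN1CCC(C(=O)N2Cc3c(NC(=O)c4ccco4)n[nH]c3C2(C)C)CC1` reports only a limit, > 5000 nM, in this assay, consistent with the limit of > 5000 nM in this assay, at which 1 of the 2 values shown sits. Compound 3 `CN(C)CC(=O)Nc1n[nH]c2c1CN(C(=O)C(C)(C)C)C2(C)C` is not yet measured; it differs from compound 1 by (dimethylamino)methyl in place of 1-methylpiperidin-4-yl on a carbonyl carbon. Going by the values given here, no measured pair covers this change, so the direction rests on the change alone. A modest loss beyond the scatter is expected, as the step of a 2.6-fold higher number from compound 1 to compound 3 (0.41 log units; beyond the scatter). Compound 3 is therefore estimated at 900 nM in this assay, within 250 nM to 3500 nM.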

Compound 3, half-maximal inhibitory concentration: 580 nM
For compound 3 the middle estimate is 1.6-fold (0.19 log units) above the measured one; the measured number falls inside the stated range.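

In this assay, (dimethylamino)methyl in place of 1-methylpiperidin-4-yl on a carbonyl carbon gives a 1.7-fold higher number from compound 1 to compound 3 (0.22 log units; within the scatter). This position therefore tolerates loss of the six-membered non-aromatic ring, with no difference beyond the scatter, and an open-chain amine serves here as well as the ring did. No measured property in the data bears on this change.

Still open, as far as these compounds go, is whether the amine itself is needed: a plain methyl or a carboxylic acid at this place would test that. A longer chain carrying the dimethylamino group would show how far the amine can sit from the carbonyl.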